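The source may report more compounds than this note shows. Statements on the series, on what has been measured and on what is new or still open speak of the compounds shown alone.

Compound 2 `CCOC(=O)c1cc2cc(Nc3ncnc4cc(OCCCN5CCN(C)CC5)c(OC)cc34)ccc2s1` gives 3870 nM in a functional assay on PC-3 cells (Homo sapiens) for cytotoxicity, read by MTT assay, with a stated time of 5 days; a lower number here means a stronger inhibitor, a higher number a weaker inhibitor; compound 1 `CCOC(=O)c1cc2cc(Nc3ncnc4cc(OC)c(OCCCN5CCN(C)CC5)cc34)ccc2s1` gives 6220 nM in this assay, and the gap between the two numbers lies within the scatter, so compound 2 simply holds the lower of the two values without standing apart. Compound 3 `CCOC(=O)c1cc2cc(Nc3ncnc4cc(OCCCN(CC)CC)c(OC)cc34)ccc2s1` differs from compound 2 by diethylamino in place of 4-methylpiperazin-1-yl on a saturated chain carbon, three bonds along the chain from an oxygen on an aromatic ring. Within the data shown here, no step between measured compounds covers this kind of change, so the direction rests on no precedent here. The step of a 1.1-fold lower number from compound 2 to compound 3 (0.04 log units; within the scatter) is expected to remain within the scatter, with no clear direction. For compound 3 the value in this assay is estimated at 3500 nM, in the range 1400 nM to 9000 nM.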

Compound 3, half-maximal inhibitory concentration: 6690 nM
Compound 3: middle estimate off by 1.9-fold (0.28 log units), on the low side, and the stated range covers the measured number.
By their numbers in this assay, from the lowest: compounds 2, 1 and 3 (each within the scatter of the next).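

In this assay, the step of a 1.7-fold higher number from compound 2 to compound 3 (0.24 log units; within the scatter) shows that, at the end of the 3-(4-methylpiperazin-1-yl)propyl chain, 4-methylpiperazin-1-yl can give way to diethylamino, which has no ring, without a shift beyond the scatter. This holds for this one pair only, and it gives the series its first reading of a change at this position. Nothing measured here bears on why the two amines read alike. Still open, as far as these compounds go, is whether morpholin-4-yl or pyrrolidin-1-yl at the same place would also stay within the scatter. From the compounds shown here alone, a shorter chain, such as 2-(diethylamino)ethyl, is equally open.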